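A few compounds are considered here, and "the series" means these few. Any claim that something is new, unique, unknown or untested is made for them only; others in the source may bear on it.

Of the compounds shown here, two sharing the same core have been measured in a functional assay on Lu cells (Homo sapiens) for antiproliferative activity; a higher number here means a weaker inhibitor, a lower number a stronger inhibitor. Compound 1, `COc1cc(/C=C/C(=O)c2ccc(OCCn3cc(CN4C(=O)/C=C/C(C)(C)C/C=C(\C)CC/C=C/4C)nn3)cc2O)cc(OC)c1OC`, gives 1.28 ug/mL. Compound 2, `COc1ccc(/C=C/C(=O)c2ccc(OCCCN3C(=O)/C=C/C(C)(C)C/C=C(\C)CC/C=C/3C)cc2)cc1`, gives 2.56 ug/mL. Within the data shown here, of these two numbers, the one for compound 2 is the higher, and the number for compound 1 sits within the usual scatter of it, so the two compounds cannot be told apart on this evidence.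

Among the measured compounds shown here, the next compound, compound 3, `COc1ccccc1/C=C/C(=O)c1ccc(OCCCN2C(=O)/C=C/C(C)(C)C/C=C(\C)CC/C=C/2C)cc1`, keeps every atom of compound 2 and rearranges only one group: 2-methoxyphenyl in place of 4-methoxyphenyl on a double-bonded chain carbon bound to a double-bonded chain carbon. A 2-methoxyphenyl stands where compound 2 carries a 4-methoxyphenyl, on a double-bonded chain carbon bound to a double-bonded chain carbon.

For the measured compounds named here, no measured pair here shows what such a change does in this assay, so the direction cannot be read from the data, and a step no larger than the scatter is expected, in either direction. Compound 3 is therefore expected to give about 2.5 ug/mL, with a range from 1 ug/mL to 6 ug/mL. The step from compound 2 to compound 3 that this estimate implies is a 1.0-fold lower number from compound 2 to compound 3 (0.01 log units; within the scatter).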

Compound 3, half-maximal inhibitory concentration: 2.82 ug/mL
Beside the measured number, compound 3's estimate is 1.1-fold (0.05 log units) below it; low and high end bracket the measured number.
By their numbers in this assay, from the lowest: compounds 1, 2 and 3 (each within the scatter of the next, the first and the last beyond it).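

In this assay, among these compounds, replacing 4-methoxyphenyl with 2-methoxyphenyl gives a 1.1-fold higher number from compound 2 to compound 3 (0.04 log units; within the scatter), and this is the first comparison here in which only one thing differs, as no earlier pair differed in just one place. The two compounds contain the same atoms, so this single step shows that rearranging this one group on a double-bonded chain carbon bound to a double-bonded chain carbon produces no difference that this read-out can separate from ordinary scatter. No supporting measurement is available to explain this result, so the step can only be recorded as it stands.

Among the compounds shown here, this one pair covers only two methoxyphenyl groups at this place, so it remains open whether a plain phenyl, or a phenyl carrying an amine or a carboxylic acid, would also fall within the scatter of compound 2. Going by these compounds, it also remains open whether the same swap would give a similar result on the different chain of compound 1, which carries other groups as well.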